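A Second Hydroxy on the Amide Chain

This account rests on a few compounds, and the source may have more. Where it says the series, first, only, none or still open, it means among the compounds named here.

In an assay on HEK293 cells for displacement of a labelled ligand from adenosine receptor A2b (Homo sapiens), read by scintillation counting, with a stated time of 30 min, tested at 10 uM (on this read-out higher numbers stand for more inhibition at the one concentration tested (going by the name of the read-out) and lower numbers for less inhibition), compound 3 `O=C(NCCCO)c1cc2cccc(O)c2oc1=O` gives 24%, the second highest of three numbers: compound 1 `COc1cccc2cc(C(=O)NCC(O)CO)c(=O)oc12` gives 25%, within the scatter, and compound 2 `O=C(NCCCO)c1cc2ccccc2oc1=O` gives 19%, also within the scatter. Within the data shown here, the only single-place step among them, a number 5 percentage points higher from compound 2 to compound 3 (within the scatter), concerns a hydroxy on an aromatic carbon and stays within the scatter. Compound 4 `O=C(NCC(O)CO)c1cc2cccc(O)c2oc1=O` differs from compound 3 by hydroxy in place of hydrogen on a saturated chain carbon bound to two saturated chain carbons. Among the measured compounds shown here, no measured step covers this chain change; compound 1, which carries the same 2,3-dihydroxypropyl chain, shows a number within the scatter of compound 3, but it differs elsewhere as well. For compound 4 the expected step is a number 1 percentage points higher from compound 3 to compound 4 (within the scatter), within the scatter. Compound 4 is estimated at 25% in this assay, between 10% and 40%.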

Compound 4, a percentage reported as inhibition, at one concentration (the size of the read-out at that concentration, not a potency): 29%
Beside the measured number, compound 4's estimate is 4 percentage points below it; the measured number falls inside the stated range.
By their numbers in this assay, from the lowest: compounds 2, 3, 1 and 4 (each within the scatter of the next).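

In this assay the chain change now has its own reading: the step from 3-hydroxypropyl to 2,3-dihydroxypropyl, a number 5 percentage points higher from compound 3 to compound 4 (within the scatter), adds a hydroxy on this saturated chain carbon without leaving the scatter. The change on the aromatic oxygen also gets its first reading, with hydrogen in place of methyl giving a number 4 percentage points higher from compound 1 to compound 4 (within the scatter) and likewise staying within the scatter. No evidence bearing on either step is available. The compounds shown leave open whether an amine or a carboxylic acid in place of the chain hydroxy, or a longer chain, would give a step beyond the scatter.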